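Methyl in place of hydrogen on compound 3

This account rests on a few compounds, and the source may have more. Where it says the series, first, only, none or still open, it means among the compounds named here.

Values in a functional assay on MCF7 cells (Homo sapiens) for antiproliferative activity, read by sulforhodamine B assay, with a stated time of 48 h (a higher number here means a weaker inhibitor, a lower number a stronger inhibitor), for the series:
- compound 1 `O=C(CCCCCCN1C(=O)/C(=N\O)c2cc(Cl)ccc21)NO` gives 680 nM
- compound 2 `O=C(CCCCCCN1C(=O)/C(=N\O)c2cc(Br)ccc21)NO` gives 1770 nM
- compound 3 `CO/N=C1/C(=O)N(CCCCCCC(=O)NO)c2ccccc21` gives 1710 nM

Compound 3 at 1710 nM lies within the scatter of compound 2 at 1770 nM and has the higher number against compound 1 at 680 nM beyond the scatter.

Compound 4 `CO/N=C1/C(=O)N(CCCCCCC(=O)NO)c2ccc(C)cc21` has not yet been measured. It carries methyl in place of hydrogen on an aromatic carbon of compound 3 (methyl in place of hydrogen on an aromatic carbon).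

Within the data shown here, only one measured step bears on this change: a 2.6-fold higher number from compound 1 to compound 2 (0.42 log units; beyond the scatter) for bromo in place of chloro on an aromatic carbon, a modest step beyond the scatter. It swaps one substituent for another, so it is only a rough guide. Among the measured compounds shown here, no measured pair shows hydrogen being replaced on that ring, and compound 1 and compound 2 each differ from compound 3 in more than one place.

A step no larger than that one is therefore expected, with no firm direction. The estimated change is a 1.3-fold lower number from compound 3 to compound 4 (0.12 log units; within the scatter) and it would stay within the scatter. Compound 4 is expected at 1300 nM with 550 nM to 3000 nM as the estimated range.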

Compound 4, half-maximal inhibitory concentration: 16700 nM
Beside the measured number, compound 4's estimate is 13-fold (1.11 log units) below it, outside the stated range (above it).
By their numbers in this assay, from the lowest: compound 1; then compounds 3 and 2 (each within the scatter of the next); then compound 4.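

Methyl in place of hydrogen on an aromatic carbon of the shared core is not a neutral change in this assay: it gives a 9.8-fold higher number from compound 3 to compound 4 (0.99 log units; beyond the scatter) and shows that this ring carbon can respond strongly to the addition of a single carbon atom. Among these compounds, this is the first measured replacement of hydrogen on that ring, and the only other step available, a 2.6-fold higher number from compound 1 to compound 2 (0.42 log units; beyond the scatter) for bromo in place of chloro, is smaller and swaps one substituent for another. The compounds shown give no measurement that accounts for the size of the methyl step.

On these data alone, whether this loss is particular to methyl or extends to other groups remains open, and a fluoro, methoxy or amino group on the same ring carbon of compound 3 would help separate these possibilities. It is also unresolved whether methyl has a comparable effect when the methoxyimino group of compound 3 is replaced by the hydroxyimino group carried by compound 1 and compound 2, so the step cannot yet be extended beyond this single pair.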